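A few compounds are considered here, and "the series" means these few. Any claim that something is new, unique, unknown or untested is made for them only; others in the source may bear on it.

In a functional assay on 4T1 cells (Mus musculus) for cytotoxicity, read by MTT assay, with a stated time of 24 h (a higher number here means a weaker inhibitor, a lower number a stronger inhibitor), compound 1 (`Cc1ccc(/C=C2\CN(C(=S)SCc3cn(Cc4ccc(F)cc4)nn3)C/C(=C\c3ccc(C)cc3)C2=O)cc1`) gives 29300 nM and stands within the scatter of compound 3 (`Cc1ccc(/C=C2\CN(Cc3cn(Cc4ccccc4F)nn3)C/C(=C\c3ccc(C)cc3)C2=O)cc1`) at 18000 nM and clearly above compound 2 (`O=C1/C(=C/c2ccccc2F)CN(Cc2cn(Cc3ccccc3Cl)nn2)C/C1=C\c1ccccc1F`) at 5300 nM on this scale. Compound 4 (`Cc1ccc(/C=C2\CN(C(=S)SCc3cn(Cc4ccccc4Cl)nn3)C/C(=C\c3ccc(C)cc3)C2=O)cc1`) is compound 1 with 2-chlorophenyl in place of 4-fluorophenyl on a saturated chain carbon bound to an aromatic nitrogen. Among the compounds with values here, compound 2 also carries 2-chlorophenyl but differs from compound 1 elsewhere too, and no measured pair isolates this change. No step beyond the scatter is therefore expected in this assay and the estimate is a 1.5-fold lower number from compound 1 to compound 4 (0.17 log units; within the scatter) towards a slightly lower number. Compound 4 is expected at 20000 nM (estimated range 8000 nM to 50000 nM).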

Compound 4, half-maximal inhibitory concentration: 49300 nM
Compound 4: middle estimate off by 2.5-fold (0.39 log units), on the low side; low and high end bracket the measured number.
By their numbers in this assay, from the lowest: compound 2; then compounds 3, 1 and 4 (each within the scatter of the next, the first and the last beyond it).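

In this assay, within the data shown here, this pair is the first to isolate the position and gives a 1.7-fold higher number from compound 1 to compound 4 (0.23 log units; within the scatter) as its step. Compound 1 and compound 4 therefore cannot be told apart, even though the 4-fluorobenzyl to 2-chlorobenzyl change alters both the halogen and its place on the ring. No available evidence bears on this result.

The separate contributions of the halogen and its ring position remain unresolved. Also open, going by these compounds, is whether an amine or carboxylic acid on the benzyl ring, or a longer chain in place of benzyl, would give a step beyond the scatter.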